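A few compounds are considered here, and "the series" means these few. Any claim that something is new, unique, unknown or untested is made for them only; others in the source may bear on it.

Measured compounds:
- compound 1, `Cc1cccc(Cn2c(CN3CCN(C(=O)C4CCCCC4)CC3)nc3ccccc32)c1`: 31.9%
- compound 2, `Cc1ccc(C(=O)N2CCN(Cc3nc4ccccc4n3Cc3cccc(C)c3)CC2)cc1`: 64.9%
- compound 3, `Cc1cccc(Cn2c(CN3CCN(C(=O)c4ccco4)CC3)nc3ccccc32)c1`: 73.2%

In an assay on isolated protein for inhibition of aldehyde dehydrogenase 1A1 (Homo sapiens), read by spectrophotometry, tested at 10 uM (on this read-out lower numbers stand for less inhibition and higher numbers for more inhibition at the one concentration tested (going by the name of the read-out)), compound 3 gives 73.2%, the highest of the three numbers. Compound 2 lies close to it, the step of a number 8.3 percentage points higher from compound 2 to compound 3 (within the scatter) being within the scatter, so no order between compounds 2 and 3 can be claimed. Compound 1 lies far below: a number 41.3 percentage points higher from compound 1 to compound 3 (beyond the scatter).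

Compound 4, `Cc1cccc(Cn2c(CN3CCN(C(=O)C(C)C)CC3)nc3ccccc32)c1`, has not yet been measured. It differs from compound 3 in one place: isopropyl in place of furan-2-yl on a carbonyl carbon. Going by the values given here, two measured steps bear on this change. Both the step of a number 33 percentage points higher from compound 1 to compound 2 (beyond the scatter) and the step of a number 41.3 percentage points higher from compound 1 to compound 3 (beyond the scatter) move from cyclohexyl on the carbonyl carbon to a ring-bearing group and rise by a large amount. Compound 4 returns to a group without a ring, so the reverse direction is expected in this assay: a large drop, of the size a number 38.2 percentage points lower from compound 3 to compound 4 (beyond the scatter). The number for compound 4 is therefore estimated at 35%, with a range from 15% to 55%.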

Compound 4, a percentage reported as inhibition, at one concentration (the size of the read-out at that concentration, not a potency): 87.2%
Estimate against measurement, compound 4: 52.2 percentage points below; the measured number lies above the stated range.
By their numbers in this assay, from the lowest: compound 1; then compounds 2 and 3 (each within the scatter of the next); then compound 4.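

In this assay, compound 4 shows that the carbonyl carbon needs no ring for a high number, since isopropyl in place of furan-2-yl gives a number 14 percentage points higher from compound 3 to compound 4 (beyond the scatter), and isopropyl in place of 4-methylphenyl gives a number 22.3 percentage points higher from compound 2 to compound 4 (beyond the scatter). Cyclohexyl, the one other group without an aromatic ring, gives a number 55.3 percentage points higher from compound 1 to compound 4 (beyond the scatter), so the two groups free of aromatic rings now stand at opposite ends of the series and having such a ring does not sort these four compounds. Nothing available explains why isopropyl outdoes the other three groups.

From the compounds shown here alone, it remains open whether a methyl, a tert-butyl, a cyclopropyl or a longer chain such as n-butyl on this carbonyl carbon would give a number nearer compound 4 or compound 1. A reading at one concentration also leaves the potency of compound 4 open.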